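A few compounds are considered here, and "the series" means these few. Any claim that something is new, unique, unknown or untested is made for them only; others in the source may bear on it.

Of the compounds shown here, three have been tested in a functional assay on cells for antagonist activity at C-X-C chemokine receptor type 4 (Homo sapiens), read by fluorescence and calcium flux, with stated times of 25 min and 90 s (a lower number here means a stronger inhibitor, a higher number a weaker inhibitor), and one more awaits its number. Compound 1 `c1ccc(CN(CCCCN(C[C@H]2Cc3ccccc3CN2)[C@H]2CCCc3cccnc32)Cc2ccccn2)nc1` gives 664 nM in this assay. Compound 2 `c1ccc(CN(CCCCN(C[C@H]2Cc3ccccc3CN2)[C@H]2CCCc3cccnc32)Cc2ccccc2)cc1` returns only a limit, > 16700 nM, and that limit is the one at which (the limit of > 16700 nM in this assay, at which 1 of the 3 values shown sits). Compound 3 `c1ccc2c(c1)CN[C@@H](CN(CCCCNCC1CCSCC1)[C@H]1CCCc3cccnc31)C2` gives 69.6 nM in this assay; it has the lowest of the two numbers that were measured, and compound 1 sits well beyond the scatter above it. No two of these three differ in a single place, so none of the gaps between them can be tied to one structural change.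

Compound 4 `CC(C)(CN)CCN(C[C@H]1Cc2ccccc2CN1)[C@H]1CCCc2cccnc21` has not yet been measured in this assay. It differs from compound 3 in one place: a group of 5 heavy atoms (4 carbon, 1 nitrogen; no ring) in place of a group of 10 heavy atoms (8 carbon, 1 nitrogen, 1 sulfur; one six-membered non-aromatic ring with 1 hetero atom), on a saturated chain carbon, two bonds along the chain from an amine nitrogen. The shared core with its two ring systems and the amine-bearing chain is kept; the change sits at the end of the chain, where a smaller group without a ring stands in for a larger one carrying a six-membered non-aromatic ring with one hetero atom. Nothing measured here shows the effect of removing such a group, so the expectation rests on the size of the change alone. For compound 4 a somewhat weaker result is expected, the step of a 2.2-fold higher number from compound 3 to compound 4 (0.33 log units; beyond the scatter), and its value in this assay is estimated at 150 nM, within a range from 30 nM to 800 nM.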

Compound 4, half-maximal inhibitory concentration: 69 nM
Compound 4: middle estimate off by 2.2-fold (0.34 log units), on the high side, and the stated range covers the measured number.
By their numbers in this assay, from the lowest: compounds 4 and 3 (each within the scatter of the next); then compound 1. At a limit, above all of these: compound 2.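

At this saturated chain carbon, two bonds along the chain from an amine nitrogen, 1-(aminomethyl)-1-methylethyl takes the place of a larger group carrying a six-membered non-aromatic ring with a sulfur atom, and this assay records a 1.0-fold lower number from compound 3 to compound 4 (0.00 log units; within the scatter) for this swap. In this one pair, then, neither the ring nor the sulfur is needed to hold the result, and the end of the chain accepts two quite differently shaped groups, which share 1 nitrogen and 1 hydrogen-bond donor. No measurement shown here accounts for why the two groups perform alike.

From the compounds shown here alone, whether that shared nitrogen matters remains open, and a group with a hydroxyl in place of the amine, or a plain isobutyl group with no nitrogen at all, would test it directly. Also open, going by these compounds, is how much room this position allows, for instance for a longer chain ending in an amine or for a piperidine ring with nitrogen where the sulfur stood.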